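The compounds below may be only part of what the source reports. "The series", "measured", "known", "first", "only" and "open" are said of these compounds alone.

Compound 1 `COc1ccc(COc2ccc(-c3nn(CCC#N)c(=S)o3)cc2)cc1` gives 910 nM in an assay for inhibition of Amine oxidase [flavin-containing] B (Rattus norvegicus); a lower number here means a stronger inhibitor, a higher number a weaker inhibitor. Compound 2 `N#CCCN1N=C(c2ccc(OCc3ccccc3)cc2)OCC1=O` gives 18 nM. Compound 3 `COc1cccc(COc2ccc(C3=NN(CCC#N)C(=O)CO3)cc2)c1` gives 68 nM.

Compound 3 thus stands second highest of the three numbers: compound 2 gives a lower number, compound 1, with a different core, a much higher one. Compound 4 `Cc1cccc(COc2ccc(C3=NN(CCC#N)C(=O)CO3)cc2)c1` differs from compound 3 only by methyl in place of methoxy on an aromatic carbon, meta to a large group. Among the compounds with values here, the one step that bears on this is a 3.8-fold higher number from compound 2 to compound 3 (0.58 log units; beyond the scatter), where a methoxy entering at this carbon raised the number. The methyl that enters here is smaller and carries no hydrogen-bond acceptor, so a partial return toward compound 2 is expected, likely within the scatter: a 1.7-fold lower number from compound 3 to compound 4 (0.23 log units; within the scatter). Compound 4 is therefore estimated at 40 nM, within a range of 15 nM to 120 nM.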

Compound 4, half-maximal inhibitory concentration: 31 nM
Beside the measured number, compound 4's estimate is 1.3-fold (0.11 log units) above it, within the range that was stated.
By their numbers in this assay, from the lowest: compounds 2 and 4 (each within the scatter of the next); then compound 3; then compound 1.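

In this assay, methyl in place of methoxy gives a 2.2-fold lower number from compound 3 to compound 4 (0.34 log units; beyond the scatter), so the number at this carbon depends on which group sits there. Methyl in place of hydrogen gives a 1.7-fold higher number from compound 2 to compound 4 (0.24 log units; within the scatter), which means that, unlike methoxy, methyl cannot be told apart from hydrogen here. Nothing measured explains why the two groups differ. Still open, as far as these compounds go, is how fluorine, an amine or a longer chain such as ethyl would compare at this carbon. Also open, from the compounds shown here alone, is whether methyl or methoxy would give the same result on other carbons of this ring.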